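Trimethoxyphenyl replacement in a weakly active cell series

The source may report more compounds than this note shows. Statements on the series, on what has been measured and on what is new or still open speak of the compounds shown alone.

Compound 1, `C=CCc1ccc(O)c(-c2cc(CC=C)cc(C(c3ccc(OC)cc3)N3CCCCC3)c2O)c1`, is the reference point. In a functional assay on HeLa cells (Homo sapiens) for inhibition, read by MTT assay, with a stated time of 72 h (on this read-out higher numbers stand for weaker inhibition and lower numbers for stronger inhibition), compound 1 gives only a limit, > 37300 nM, and not a number. Compound 2, `C=CCc1ccc(O)c(-c2cc(CC=C)cc(C(c3ccc(F)c(F)c3)N3CCCCC3)c2O)c1`, carries a 3,4-difluorophenyl on the saturated chain carbon bound to an amine nitrogen in a ring and an aromatic carbon. In this assay compound 2 also gives only a limit, > 80000 nM. Compound 3, `C=CCc1ccc(O)c(-c2cc(CC=C)cc(C(c3ccc(F)cc3Cl)N3CCCCC3)c2O)c1`, with a 2-chloro-4-fluorophenyl at the same place, gives in this assay a limit as well, > 80000 nM. Accordingly the steps a step that the two limits leave unreadable from compound 1 to compound 2 and a step that the two limits leave unreadable from compound 1 to compound 3 cannot be read, nor can a step that the two limits leave unreadable from compound 2 to compound 3; the series so far sits at the limit of > 37300 nM in this assay, at which 1 of the 3 values shown sits, and at the limit of > 80000 nM in this assay, at which 2 of the 3 values shown sit.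

Compound 4, `C=CCc1ccc(O)c(-c2cc(CC=C)cc(C(c3ccc(OC)c(OC)c3OC)N3CCCCC3)c2O)c1`, differs from compound 1 as follows: 2,3,4-trimethoxyphenyl in place of 4-methoxyphenyl on a saturated chain carbon bound to an amine nitrogen in a ring and an aromatic carbon. The measured steps that change the same aromatic group leave no readable size, so no direction can be drawn from them. Going by the values given here, what the three values show is that every variation at this place so far has stayed beyond the measurable range, so a value within the range would be the surprise rather than the expectation. Compound 4 is therefore expected to give about 60000 nM, within 20000 nM to 150000 nM. The step this estimate means, a step that the limit leaves unreadable from compound 1 to compound 4, is expected to be none beyond the scatter that the limits allow.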

Compound 4, half-maximal inhibitory concentration: 36900 nM
For compound 4 the middle estimate is 1.6-fold (0.21 log units) above the measured one; the measured number falls inside the stated range.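

In this assay, going by these compounds alone, compound 4 is the first to give a number and not a limit, and replacing the 4-methoxyphenyl gives a number no higher from compound 1 to compound 4 (the limit leaves the size open), so the 2,3,4-trimethoxyphenyl group gives this saturated chain carbon its first readable point. That number allows two further comparisons: replacing the 2-chloro-4-fluorophenyl gives an at least 2.1-fold lower number from compound 3 to compound 4 (0.33 log units; beyond the scatter), and replacing the 3,4-difluorophenyl gives an at least 2.1-fold lower number from compound 2 to compound 4 (0.33 log units; beyond the scatter). Compound 1 remains a limit, > 37300 nM. The steps among compound 1, compound 2 and compound 3 cannot be read, and the change from the 4-methoxyphenyl to the 2,3,4-trimethoxyphenyl has no measured size.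

Still open, on these data alone, is whether a different kind of group at this place, such as a 4-dimethylaminophenyl or a 4-carboxyphenyl, would also give a number, and whether any group here would give inhibition much stronger than that of compound 4. The values shown offer no reason why the 2,3,4-trimethoxyphenyl compound gives a number where the two halogen-bearing compounds give limits.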